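Removing a hydroxy from the side chain of compound 3

The source may report more compounds than this note shows. Statements on the series, on what has been measured and on what is new or still open speak of the compounds shown alone.

Of the compounds shown here, three sharing one core have been measured in an assay on HEK293 cells for inhibition of Steryl-sulfatase (Homo sapiens), tested at 0.1 uM; a lower number here means a weaker effect, a higher number a stronger effect of the compound at the concentration tested. Compound 1 `NS(=O)(=O)Oc1ccc2c(c1)CN(C(=O)c1cccc(N3CCCCC3)c1)CC2` gives 1%, compound 2 `CCN(Cc1ccc(F)cc1)c1cccc(C(=O)N2CCc3ccc(OS(N)(=O)=O)cc3C2)c1` gives 10.9%, and compound 3 `NS(=O)(=O)Oc1ccc2c(c1)CN(C(=O)c1cccc(N(CCCO)Cc3ccccc3)c1)CC2` gives 25.8%, the highest of the three numbers. Going by the values given here, the only measured step is a number 9.9 percentage points higher from compound 1 to compound 2 (within the scatter), a change elsewhere on the shared core. Compound 4 `CCCN(Cc1ccccc1)c1cccc(C(=O)N2CCc3ccc(OS(N)(=O)=O)cc3C2)c1` differs from compound 3 by hydrogen in place of hydroxy on a saturated chain carbon, three bonds along the chain from a nitrogen on an aromatic ring. Among the compounds with values here, no measured step concerns this change, so the expectation rests only on the two benzyl-bearing compounds 2 and 3, whose values bracket a modest range. The estimated step is a number 7.8 percentage points lower from compound 3 to compound 4 (within the scatter), a small decrease that may lie within the scatter. Compound 4 is therefore expected to give about 18%, between 5% and 35%.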

Compound 4, a percentage reported as inhibition, at one concentration (the size of the read-out at that concentration, not a potency): 23.1%
For compound 4 the middle estimate is 5.1 percentage points below the measured one; the measured number falls inside the stated range.
By their numbers in this assay, from the lowest: compounds 1 and 2 (each within the scatter of the next); then compounds 4 and 3 (each within the scatter of the next).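

In this assay the step of a number 2.7 percentage points lower from compound 3 to compound 4 (within the scatter) shows that going from 3-hydroxypropyl to propyl leaves the read-out within the usual scatter, so this hydroxy is not needed to hold it. The steps of a number 12.2 percentage points higher from compound 2 to compound 4 (beyond the scatter) and a number 22.1 percentage points higher from compound 1 to compound 4 (beyond the scatter) show that benzyl(propyl)amino, even without a hydroxy, still stands apart from ethyl(4-fluorobenzyl)amino and piperidin-1-yl. No available evidence bears on these numbers. Still open, as far as these compounds go, is whether 3-aminopropyl, a carboxylic acid or a longer chain such as butyl in place of propyl would give a similar number.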